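This account rests on a few compounds, and the source may have more. Where it says the series, first, only, none or still open, it means among the compounds named here.

Working notes on the series. In an ADME assay on MRC5 cells (Homo sapiens) for inhibition, read by MTT assay, with a stated time of 72 h (on this read-out lower numbers stand for stronger inhibition and higher numbers for weaker inhibition), compound 1 `O=C(OCCCCCCOC(=O)OCCc1ccc(OCc2ccccc2)c(OCc2ccccc2)c1)OCCc1ccc(OCc2ccccc2)c(OCc2ccccc2)c1` has the entry "not determined" (no result reported), so it gives no reference point. Compound 2 `O=C(OCCCCCCCCO)OCCc1ccc(O)c(O)c1` reads > 50000 nM, which is a limit of the assay and not a number. Compound 3 `O=C(OCCCCCCCCOC(=O)OCCc1ccc(O)c(O)c1)OCCc1ccc(O)c(O)c1` reads > 50000 nM, which is also a limit. Taken together, (the limit of > 50000 nM in this assay, at which 2 of the 3 values shown sit), and no measured compound in this assay yet has a numerical value.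

The next comparison is compound 2 against compound 4 `CCCCCCCCCCCCOC(=O)OCCc1ccc(O)c(O)c1`. The change is butyl in place of hydroxy on a saturated chain carbon, eight bonds along the chain from an oxygen next to a carbonyl group. Within the data shown here, no measured pair shows what a change of this kind does, so the expectation is tentative. A modest shift toward stronger inhibition is expected, and a result that again stops at the limit would be no surprise. The expected step is an at least 1.6-fold lower number from compound 2 to compound 4 (0.22 log units; that floor lies within the scatter). For compound 4 the estimated value is 30000 nM, with an expected range of 10000 nM to 60000 nM.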

Compound 4, half-maximal inhibitory concentration: 12400 nM
Compound 4: middle estimate off by 2.4-fold (0.38 log units), on the high side; the measured number falls inside the stated range.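

Among these compounds, compound 4 gives the first numerical value in this assay, so the place on a saturated chain carbon, eight bonds along the chain from an oxygen next to a carbonyl group, now has a readable change. Butyl in place of hydroxy there gives an at least 4.0-fold lower number from compound 2 to compound 4 (0.60 log units; beyond the scatter). That step is a floor and not a measured size, because compound 2 stands at a limit: the limit of > 50000 nM in this assay, at which 2 of the 4 values shown sit.

The compounds shown leave open whether the step follows from the hydroxy leaving or from the butyl entering, as the two come together in this one change. As far as these compounds go, how an amine, a carboxylic acid or a longer chain at this place would read in this assay also remains open.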